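Dropping the Cyano Group: What the Limits Allow

The compounds below may be only part of what the source reports. "The series", "measured", "known", "first", "only" and "open" are said of these compounds alone.

Of the compounds shown here, three built on one shared core have been tested in a functional assay on cells (Rhabdomyosarcoma cell, Homo sapiens) for cytotoxicity; on this read-out lower numbers stand for stronger inhibition and higher numbers for weaker inhibition. Compound 1 `Brc1ccc(C(c2ccccc2)N2CCN(c3ncnc4c3cnn4-c3ccccc3)CC2)cc1` gives > 25000 nM, which is a limit of the assay rather than a number. Compound 2 `N#Cc1cccc(C(c2ccccc2)N2CCN(c3ncnc4c3cnn4-c3ccccc3)CC2)c1` gives > 25000 nM, again a limit. Compound 3 `FC(F)(F)c1ccc(C(c2ccccc2)N2CCN(c3ncnc4c3cnn4-c3ccccc3)CC2)cc1` gives > 25000 nM, also a limit. Compound 2 therefore stands at the same limit as the other two, and nothing in this assay separates the three; indeed (the limit of > 25000 nM in this assay, at which 3 of the 3 values shown sit).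

Compound 4 `c1ccc(C(c2ccccc2)N2CCN(c3ncnc4c3cnn4-c3ccccc3)CC2)cc1` is the unmeasured partner of compound 2. The change is hydrogen in place of cyano on an aromatic carbon. The closest comparisons are the measured steps a step that the two limits leave unreadable from compound 1 to compound 2, a step that the two limits leave unreadable from compound 1 to compound 3 and a step that the two limits leave unreadable from compound 2 to compound 3. None of them could be read, because of the limit of > 25000 nM in this assay, at which 3 of the 3 values shown sit. So the measured steps give no size in either direction for the change to compound 4; they show only that exchanging one substituent on this phenyl ring for another has not yet produced a readable number in this assay.

The expectation is that compound 4 behaves like its neighbours and also stays at the limit, so the step that the limit leaves unreadable from compound 2 to compound 4 is expected to be nothing readable. Compound 4 is estimated at 40000 nM, within the range 12000 nM to 150000 nM.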

Compound 4, half-maximal inhibitory concentration: > 25000 nM
Compound 4 was reported as a limit (the forecaster's own chance of this, stated with the estimate: 85%); the middle value does not contradict the limit.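

Compound 4 gives no readable step to compound 1, compound 2 or compound 3, because all four compounds stand at the same limit of the assay: the limit of > 25000 nM in this assay, at which 4 of the 4 values shown sit.

Still open, on these data alone, is whether any other group on this phenyl ring, or any change elsewhere on the shared core, would give a real number in this assay at all.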